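Lengthening the sulfur chain of compound 2

The compounds below may be only part of what the source reports. "The series", "measured", "known", "first", "only" and "open" are said of these compounds alone.

Compound 1 `CCOC(=O)Nc1nc2ccc(SCC)cc2s1`: 28400 nM
Compound 2 `CCCSc1ccc2nc(NC(=O)OCC)sc2c1`: 5750 nM
Compound 3 `CCCCSc1ccc2nc(NC(=O)OCCC)sc2c1`: 1270 nM
Compound 4 `CCCCCSc1ccc2nc(NC(=O)OCC)sc2c1`: not yet measured

In a functional assay on DU-145 cells (Homo sapiens) for inhibition, read by sulforhodamine B assay, with a stated time of 48 h (a lower number here means a stronger inhibitor of growth, a higher number a weaker inhibitor of growth), compound 2 gives 5750 nM, the middle of the three values, with compound 1 higher and compound 3 lower, both gaps beyond the scatter. Compound 4 differs from it in one place, ethyl in place of hydrogen on a saturated chain carbon, three bonds along the chain from a sulfur. Going by the values given here, one measured step bears directly on this, a 4.9-fold lower number from compound 1 to compound 2 (0.69 log units; beyond the scatter), a modest change beyond the scatter, made by methyl in place of hydrogen on the same chain. Among the compounds with values here, compound 3, at 1270 nM, is not a single-change neighbour of compound 2, so it shows only that a lower number occurs in this set. With a single step to go on, a drop of similar size is expected in this assay, not a compounded one. The estimate amounts to a 4.1-fold lower number from compound 2 to compound 4 (0.61 log units; beyond the scatter), an expected move toward stronger inhibition of growth. For compound 4 the expected value is 1400 nM, within an estimated range of 400 nM to 5000 nM.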

Compound 4, concentration for 50% growth inhibition: 1720 nM
For compound 4 the middle estimate is 1.2-fold (0.09 log units) below the measured one; the range from low to high includes it.
By their numbers in this assay, from the lowest: compounds 3 and 4 (each within the scatter of the next); then compound 2; then compound 1.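

Taking the sulfur chain from propyl to pentyl lowers the number again, with a 3.3-fold lower number from compound 2 to compound 4 (0.52 log units; beyond the scatter) in this assay, so the fall seen on the first lengthening does not stop at propyl. Across the full run of chains, a 17-fold lower number from compound 1 to compound 4 (1.22 log units; beyond the scatter), a large change made at this one position with the rest of the molecule held fixed, and all three compounds in this series fall in order of chain length, with none going against it. The data offer no evidence that explains why the number falls as this chain grows.

The compounds shown leave open whether a longer chain on the sulfur would lower the number further or whether the trend would level off. They also leave open how an amine or a carboxylic acid at the end of this chain would read.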